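A few compounds are considered here, and "the series" means these few. Any claim that something is new, unique, unknown or untested is made for them only; others in the source may bear on it.

Of the compounds shown here, three measured so far share one core and differ only in the group on the aromatic ring that carries the ether oxygen: compound 1 `CCC(COc1cccc(C(F)(F)F)c1)OC(=O)NCc1ccccc1`, compound 2 `CCC(COc1ccccc1)OC(=O)NCc1ccccc1` and compound 3 `CCC(COc1cccc(OC)c1)OC(=O)NCc1ccccc1`. In an assay for inhibition of zeta-carotene desaturase, chloroplastic/chromoplastic (Capsicum annuum), using a Dixon plot, with a stated time of 8 h (a lower number here means a stronger inhibitor, a higher number a weaker inhibitor), compound 1 gives > 100000 nM, which is a limit of the assay rather than a number. Compound 2 likewise gives only a limit in this assay, > 100000 nM. Compound 3 also gives only a limit, > 100000 nM. Compound 2 therefore stands at the same limit as the other two, with no number to place it more finely. The steps between these compounds, a step that the two limits leave unreadable from compound 1 to compound 2, a step that the two limits leave unreadable from compound 1 to compound 3 and a step that the two limits leave unreadable from compound 2 to compound 3, cannot be sized, since every one of them runs from one limit to another; that is what the limit of > 100000 nM in this assay, at which 3 of the 3 values shown sit, describes. The unmeasured compound 4 `CCC(COc1cccc(C(=O)O)c1)OC(=O)NCc1ccccc1` is reached from compound 2 by the change (carboxy in place of hydrogen on an aromatic carbon). Among the compounds with values here, no measured step gives a readable size for any change on this ring, so the expected step from compound 2 to compound 4 in this assay is a number no higher from compound 2 to compound 4 (the limit leaves the size open), with no direction beyond the scatter. For compound 4 the estimate in this assay is 100000 nM, within a range from 30000 nM to 300000 nM.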

Compound 4, half-maximal inhibitory concentration: > 100000 nM
Compound 4: only a limit was reported; the forecaster's own chance of this, stated with the estimate: 80%; the middle value sits exactly at the limit.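

Within the data shown here, no step from compound 1, compound 2 or compound 3 to compound 4 can be read, because all four compounds stop at the same limit: the limit of > 100000 nM in this assay, at which 4 of the 4 values shown sit. The compounds shown leave open whether any of these groups on the ring changes inhibition at all.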